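The compounds below may be only part of what the source reports. "The series", "measured", "known", "first", "only" and "open" are said of these compounds alone.

Measured in a functional assay on VCaP cells (Homo sapiens) for antiproliferative activity, read by propidium iodide staining, with a stated time of 96 h (a lower number here means a stronger inhibitor, a higher number a weaker inhibitor), so far:
- compound 1 `CC(O)(COc1ccccc1OC(F)(F)F)C(=O)Nc1cccc(S(F)(F)(F)(F)F)c1` gives 27700 nM
- compound 2 `CC(O)(COc1ccc(S(F)(F)(F)(F)F)cc1)C(=O)Nc1cc(C(F)(F)F)cc(C(F)(F)F)c1` gives 2400 nM

Of these two values, compound 2 at 2400 nM is the lower, and its gap to compound 1 lies beyond the scatter. Compound 3 `CC(O)(COc1ccc(C(F)(F)C(F)(F)F)cc1)C(=O)Nc1cc(C(F)(F)F)cc(C(F)(F)F)c1` has not yet been measured. It differs from compound 2 in one place: a group of 7 heavy atoms (2 carbon, 5 fluorine; no ring) in place of a group of 6 heavy atoms (5 fluorine, 1 sulfur; no ring), on an aromatic carbon. The 1,1,2,2,2-pentafluoroethyl group stands on an aromatic carbon of a six-membered aromatic ring of carbon only, para to a large group, where compound 2 carries a group of 6 heavy atoms (5 fluorine, 1 sulfur).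

Within the data shown here, no measured pair shows this exchange, so the expectation rests on the structural change alone. Both groups hold 5 fluorine, no ring, 0 hydrogen-bond donors and 0 hydrogen-bond acceptors. No step beyond the scatter is expected in this assay, and no direction is favoured. The expected change is a 1.1-fold higher number from compound 2 to compound 3 (0.03 log units; within the scatter) in the estimate used here. With so few values, the range is kept wide. Compound 3 is estimated at 2600 nM with 1000 nM as the expected lower end and 6500 nM as the expected upper end.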

Compound 3, half-maximal inhibitory concentration: 3000 nM
Estimate against measurement, compound 3: 1.2-fold (0.06 log units) below; low and high end bracket the measured number.
By their numbers in this assay, from the lowest: compounds 2 and 3 (each within the scatter of the next); then compound 1.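

In this assay, 1,1,2,2,2-pentafluoroethyl in place of the group of 6 heavy atoms (5 fluorine, 1 sulfur), on an aromatic carbon para to a large group, gives a 1.3-fold higher number from compound 2 to compound 3 (0.10 log units; within the scatter), so the two compounds cannot be told apart in this read-out. Among these compounds, this is the first pair that differs in one place, and it shows that at this position the exchange between these two groups, both with 5 fluorine, no ring and no hydrogen-bond donors or acceptors, leaves the antiproliferative read-out unresolved from that of the parent, while compound 1 differs from both in more than one place and adds no comparison here. No measured property of either group is at hand that would bear on this result.

The pair leaves open how far this position accepts groups of another kind, such as an amine, a carboxylic acid or a longer perfluoroalkyl chain, and what a plain hydrogen atom there would give. It also leaves open whether the same exchange at another place on the shared core would stay within the scatter.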